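The source may report more compounds than this note shows. Statements on the series, on what has been measured and on what is new or still open speak of the compounds shown alone.

In a physicochemical assay for solubility, at pH 6.8 (on this read-out lower numbers stand for lower solubility and higher numbers for higher solubility), three related compounds have been measured. Compound 1 `Nc1ncc(-c2ccc(CN3CCC(N4CCCC4)CC3)cc2)nc1C(=O)N[C@H]1CC[C@H](O)CC1` gives > 1000000 nM; > 1000000 nM (2 entries), which is a limit of the assay and not a number. From the compounds shown here alone, compound 2 `CCN(CC)C1CCN(Cc2ccc(-c3cnc(N)c(C(=O)N[C@H]4CC[C@H](O)CC4)n3)cc2)CC1` gives > 1000000 nM, which is likewise a limit and not a number, so its exact place on the scale is unknown. Among the compounds with values here, compound 3 `CN(C)Cc1ccc(-c2cnc(N)c(C(=O)NC3CCCC3O)n2)cc1` is the only one with a number, at 940000 nM.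

Compound 4 `CC(C)N1CCN(Cc2ccc(-c3cnc(N)c(C(=O)N[C@H]4CC[C@H](O)CC4)n3)cc2)CC1` departs from compound 2 in one place, with 4-isopropylpiperazin-1-yl in place of 4-(diethylamino)piperidin-1-yl on a saturated chain carbon bound to an aromatic carbon. Within the data shown here, no measured pair in this small set shows what such an exchange does, so no shift in either direction beyond the usual scatter is expected in this assay. This expectation rests on compound 2, whose limit is > 1000000 nM. The estimated step of a number no higher from compound 2 to compound 4 (the limit leaves the size open) is therefore expected to stay within the scatter. For compound 4 the estimated value is 1000000 nM, with an expected range from 500000 nM to 2000000 nM.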

Compound 4, solubility: 830000 nM
Beside the measured number, compound 4's estimate is 1.2-fold (0.08 log units) above it; the range from low to high includes it.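

In this assay, within the data shown here, 4-isopropylpiperazin-1-yl in place of 4-(diethylamino)piperidin-1-yl on a saturated chain carbon bound to an aromatic carbon gives the first readable step at this position, an at least 1.2-fold lower number from compound 2 to compound 4 (0.08 log units; that floor lies within the scatter). Compound 2 stands at > 1000000 nM, which is a limit of the assay and not a number. Only a floor can be read for this change and it lies within the scatter, so the true size of the step stays open because compound 2 rests on a limit: the limit of > 1000000 nM in this assay, at which 1 of the 4 values shown sits.

The compounds shown leave open how a morpholin-4-yl group or a piperazine carrying a methyl group in place of isopropyl would read at this same place. They also leave open what a carboxylic acid on the isopropyl chain would do to the value of compound 4.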